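The source may report more compounds than this note shows. Statements on the series, on what has been measured and on what is new or still open speak of the compounds shown alone.

Compound 1 `COc1ccc(-c2ss/c(=N/O)c2-c2cc(OC)c(OC)c(OC)c2)cc1O`: 730 nM
Compound 2 `COc1ccc(-c2ss/c(=N/O)c2-c2cc(OC)c(OC)c(OC)c2)cc1N`: 9360 nM
Compound 3 `CO/N=c1/ssc(-c2ccc(OC)c(O)c2)c1-c1cc(OC)c(OC)c(OC)c1`: 4600 nM

In a functional assay on HT-1080 cells (Homo sapiens) for antiproliferative activity, read by MTT assay, with a stated time of 72 h (on this read-out higher numbers stand for weaker inhibition and lower numbers for stronger inhibition), compound 3 (4600 nM) stands second highest of the three. The lowest number belongs to compound 1 (730 nM), the highest to compound 2 (9360 nM). Compound 4 `CO/N=c1/ssc(-c2ccc(OC)c(N)c2)c1-c1cc(OC)c(OC)c(OC)c1` differs from compound 3 by one change (amino in place of hydroxy on an aromatic carbon): amino in place of hydroxy on an aromatic carbon. That same change was measured once and gave a large step (a 13-fold higher number from compound 1 to compound 2 (1.11 log units; beyond the scatter)). As far as these compounds go, compound 3 itself carries a modest step of its own (a 6.3-fold higher number from compound 1 to compound 3 (0.80 log units; beyond the scatter)), and whether the two steps simply add is unknown. A higher number is therefore expected, though with a smaller step than that single precedent. The expected step is a 4.3-fold higher number from compound 3 to compound 4 (0.64 log units; beyond the scatter) and rests on one pair only. Compound 4 is estimated at 20000 nM with an expected range (6000 nM to 60000 nM).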

Compound 4, half-maximal inhibitory concentration: 4230 nM
Estimate against measurement, compound 4: 4.7-fold (0.67 log units) above, outside the stated range (below it).
By their numbers in this assay, from the lowest: compound 1; then compounds 4 and 3 (each within the scatter of the next); then compound 2.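

In this assay, amino in place of hydroxy on the core of compound 3 gives a 1.1-fold lower number from compound 3 to compound 4 (0.04 log units; within the scatter), so the large step seen on the core of compound 1 does not carry over: the same change on two cores in this assay, a 13-fold higher number (1.11 log units; beyond the scatter) from compound 1 to compound 2 and a 1.1-fold lower number (0.04 log units; within the scatter) from compound 3 to compound 4, 14-fold (1.14 log units) apart, beyond the scatter of two such steps

Methyl in place of hydrogen on the oxygen also depends on its partner, raising the number when the ring carries hydroxy but giving a 2.2-fold lower number from compound 2 to compound 4 (0.34 log units; beyond the scatter) when it carries amino: the same change on two cores in this assay, a 6.3-fold higher number (0.80 log units; beyond the scatter) from compound 1 to compound 3 and a 2.2-fold lower number (0.34 log units; beyond the scatter) from compound 2 to compound 4, 14-fold (1.14 log units) apart, beyond the scatter of two such steps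

The two changes therefore do not simply add.

Still open, as far as these compounds go, is how a fluorine atom at this ring position, or an ethyl group in place of the methyl on the oxygen, would behave.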